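A few compounds are considered here, and "the series" means these few. Any claim that something is new, unique, unknown or untested is made for them only; others in the source may bear on it.

Compound 3 `CCCC(=O)Nc1ccc(-c2ccccc2)cn1` gives 22% in an assay on isolated protein (Aquatica lateralis) for inhibition of Luciferin 4-monooxygenase (Luciola lateralis), read by a luciferase reporter, tested at 10 uM; on this read-out lower numbers stand for less inhibition and higher numbers for more inhibition at the one concentration tested (going by the name of the read-out). Compound 2 `O=C(Nc1ccccc1)Nc1ccc(-c2ccccc2)cn1` gives 20% in this assay, and the two lie within the scatter of each other, so neither can be placed above the other. Compound 1 `O=C(Nc1ccc(-c2ccccc2)cn1)Oc1ccccc1` gives 0% in this assay, a clearly lower number.

Compound 4 `Cc1ccc(C(=O)Nc2ccc(-c3ccccc3)cn2)cc1` differs from compound 3 in one place: 4-methylphenyl in place of propyl on a carbonyl carbon. Among the measured compounds shown here, two measured steps bear on this carbonyl position: a number 22 percentage points higher from compound 1 to compound 3 (beyond the scatter) and a number 2 percentage points higher from compound 2 to compound 3 (within the scatter). Both compare propyl with a group carrying a six-membered aromatic ring, and neither shows the ring-bearing group giving a higher number. A step of no size beyond the scatter, or a small drop, is therefore expected for a number 7 percentage points lower from compound 3 to compound 4 (within the scatter). Compound 4 is estimated at 15%, within 0% to 35%.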

Compound 4, a percentage reported as inhibition, at one concentration (the size of the read-out at that concentration, not a potency): 18%
Compound 4: middle estimate off by 3 percentage points, on the low side; low and high end bracket the measured number.
By their numbers in this assay, from the lowest: compound 1; then compounds 4, 2 and 3 (each within the scatter of the next).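

In this assay, a carbon-only aromatic ring on the carbonyl carbon cannot be told apart from the open propyl chain (a number 4 percentage points lower from compound 3 to compound 4 (within the scatter)) or from anilino (a number 2 percentage points lower from compound 2 to compound 4 (within the scatter)). Phenoxy alone stands apart from this new ring-bearing group (a number 18 percentage points higher from compound 1 to compound 4 (beyond the scatter)), so three different groups now share one level and only phenoxy gives a clearly lower number. No evidence is available to explain this difference. Still open, as far as these compounds go, is whether a longer chain, an amine or a carboxylic acid on this carbonyl carbon would rise clearly above that level.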